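The source may hold more compounds than are shown below. What is called first, only, known or untested is meant among the compounds shown, and "the series" means these compounds.

Of the compounds shown here, three sharing one core have been tested in a functional assay on SGC-7901 cells (Homo sapiens) for cytotoxicity, read by MTT assay, with a stated time of 48 h; on this read-out lower numbers stand for stronger inhibition and higher numbers for weaker inhibition. Compound 1 `Cc1ccc(-c2nnc(SCCn3c([N+](=O)[O-])cnc3C)o2)cc1` gives 12500 nM. Compound 2 `COc1ccccc1-c1nnc(SCCn2c([N+](=O)[O-])cnc2C)o1` gives 30500 nM, and compound 3 `Cc1ncc([N+](=O)[O-])n1CCSc1nnc(-c2ccc(N)cc2)o1` gives 31700 nM. On these numbers compound 2 stands second highest of the three: its value and that of compound 3 lie within the scatter of each other, while the step of a 2.4-fold higher number from compound 1 to compound 2 (0.39 log units; beyond the scatter) is a modest weakening. The unmeasured compound 4 `Cc1cccc(-c2nnc(SCCn3c([N+](=O)[O-])cnc3C)o2)c1O` differs from compound 2 in one place: 2-hydroxy-3-methylphenyl in place of 2-methoxyphenyl on an aromatic carbon. Two measured steps alter the same aromatic carbon of the core: a 2.4-fold higher number from compound 1 to compound 2 (0.39 log units; beyond the scatter) and a 1.0-fold higher number from compound 2 to compound 3 (0.02 log units; within the scatter), the second of which stays within the scatter even though it exchanges a methoxy-bearing ring for an amino-bearing one. The step of a 2.5-fold higher number from compound 1 to compound 3 (0.40 log units; beyond the scatter) is again modest. Changes at this ring have so far shifted this assay only modestly, so no step beyond the scatter is expected for compound 4 in either direction. Compound 4 is expected to give 25000 nM in this assay, with a range from 10000 nM to 60000 nM, which corresponds to an expected step of a 1.2-fold lower number from compound 2 to compound 4 (0.09 log units; within the scatter).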

Compound 4, half-maximal inhibitory concentration: 35900 nM
Compound 4: middle estimate off by 1.4-fold (0.16 log units), on the low side; the measured number falls inside the stated range.
By their numbers in this assay, from the lowest: compound 1; then compounds 2, 3 and 4 (each within the scatter of the next).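

In this assay, the exchange of 2-methoxyphenyl for 2-hydroxy-3-methylphenyl keeps the same atoms and adds a hydrogen-bond donor, yet the step is only a 1.2-fold higher number from compound 2 to compound 4 (0.07 log units; within the scatter). With a 1.1-fold higher number from compound 3 to compound 4 (0.05 log units; within the scatter) as well, compound 2, compound 3 and compound 4 now form a group of three differently substituted rings within the scatter of one another, while compound 1, with 4-methylphenyl, stands apart from the newcomer by a 2.9-fold higher number from compound 1 to compound 4 (0.46 log units; beyond the scatter). Nothing shown here offers an explanation for this result.

In compound 4 the hydroxy and the methyl enter together, so the compounds shown cannot separate what each contributes. Also open, going by these compounds, is whether a carboxylic acid or a longer alkyl chain on this ring would match compound 1 at 12500 nM or improve on it.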